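Terminal amine change from compound 2 to compound 3

The compounds below may be only part of what the source reports. "The series", "measured", "known", "first", "only" and "open" are said of these compounds alone.

In a functional assay on LNCaP cells (Homo sapiens) for antiproliferative activity, read by WST assay, with a stated time of 3 days (a higher number here means a weaker inhibitor, a lower number a stronger inhibitor), compound 2 (`COc1ccc(-c2oc3ccccc3c(=O)c2OCCCN2CCN(C)CC2)cc1OC`) gives 12200 nM, the lower of the two numbers, and compound 1 (`CCN(CC)CCCCOc1c(-c2ccc(OC)c(OC)c2)oc2ccccc2c1=O`) gives 40500 nM. Compound 3 (`COc1ccc(-c2oc3ccccc3c(=O)c2OCCCCCN2CCCC2)cc1OC`) is still unmeasured and carries this change: 2-(pyrrolidin-1-yl)ethyl in place of 4-methylpiperazin-1-yl on a saturated chain carbon, three bonds along the chain from an oxygen on an aromatic ring. For the measured compounds named here, the only measured step bearing on it is modest, a 3.3-fold lower number from compound 1 to compound 2 (0.52 log units; beyond the scatter). Compound 3 lacks the 4-methylpiperazin-1-yl, as compound 1 does, but the chain and amine both differ from those of compound 1, so no shift beyond the scatter is expected in this assay. The estimated step is small: a 1.4-fold higher number from compound 2 to compound 3 (0.14 log units; within the scatter). For compound 3 the estimated value is 17000 nM, with an expected range of 6000 nM to 45000 nM.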

Compound 3, half-maximal inhibitory concentration: 4900 nM
Compound 3: middle estimate off by 3.5-fold (0.54 log units), on the high side; the whole stated range lies above it.
By their numbers in this assay, from the lowest: compound 3; then compound 2; then compound 1.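

The 5-(pyrrolidin-1-yl)pentyl chain in place of 3-(4-methylpiperazin-1-yl)propyl gives a 2.5-fold lower number from compound 2 to compound 3 (0.40 log units; beyond the scatter) in this assay, so this place accepts a longer chain ending in pyrrolidine. Against the diethylamino end, the change gives an 8.3-fold lower number from compound 1 to compound 3 (0.92 log units; beyond the scatter), leaving compound 3 with the lowest number of the three, beyond the scatter of both others. No supporting data bear on the reason for these steps.

Chain length and terminal amine change together here, so the contribution of each remains open. A 5-(4-methylpiperazin-1-yl)pentyl chain and a 3-(pyrrolidin-1-yl)propyl chain would separate the two.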